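Bromo for 1H-Indol-5-yl in the Ethyl Ester Series

This account rests on a few compounds, and the source may have more. Where it says the series, first, only, none or still open, it means among the compounds named here.

Compound 3 `CCOC(=O)CCCCCOc1cccc(CN(C(=O)c2ccc(-c3ccc4[nH]ccc4c3)cc2)C(C)C)c1` gives in an ADME assay on HEK293 cells (Homo sapiens) for cytotoxicity, read by CellTiter-Glo and resazurin assay, with a stated time of 72 h (on this read-out higher numbers stand for an effect only at larger amounts of compound and lower numbers for an effect already at smaller amounts), only a limit, > 26000 nM. Compound 1 `CC(C)N(Cc1cccc(OCCCCCC(=O)O)c1)C(=O)c1ccc(-c2ccc3[nH]ccc3c2)cc1` likewise reaches only a limit in this assay, > 26000 nM. Compound 2 `COc1cc(OC)cc(-c2ccc(C(=O)N(Cc3cccc(OCCCCCC(=O)O)c3)C(C)C)cc2)c1` also shows only a limit in this assay, > 26000 nM. All three values therefore stand at one boundary, (the limit of > 26000 nM in this assay, at which 3 of the 3 values shown sit), and the two measured steps, a step that the two limits leave unreadable from compound 1 to compound 2 and a step that the two limits leave unreadable from compound 1 to compound 3, cannot be read in size. Compound 4 `CCOC(=O)CCCCCOc1cccc(CN(C(=O)c2ccc(Br)cc2)C(C)C)c1` keeps the ethyl ester of compound 3 and exchanges the group on a six-membered aromatic ring of carbon only: bromo in place of 1H-indol-5-yl on an aromatic carbon. For the measured compounds named here, no measured step covers this exchange; what bears on it is only that compound 1, compound 2 and compound 3 all sit at the limit, so nothing points to an effect at the amounts tested. A step of no readable size is expected, a step that the limit leaves unreadable from compound 3 to compound 4. Compound 4 is therefore estimated to give about 30000 nM, within 12000 nM to 80000 nM, most likely again as a limit.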

Compound 4, half-maximal effective concentration: > 26000 nM
Compound 4 ended at the assay's limit (the forecaster's own chance of this, stated with the estimate: 85%); the middle value does not contradict the limit.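

For the compounds shown here, compound 3 and compound 4 both end at a limit in this assay, so no step of readable size follows from bromo in place of 1H-indol-5-yl: the limit of > 26000 nM in this assay, at which 4 of the 4 values shown sit. The compounds shown leave open at what amount, if any, compound 1, compound 2, compound 3 or compound 4 would show an effect in this assay.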